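The source may report more compounds than this note shows. Statements on the series, on what has been measured and on what is new or still open speak of the compounds shown alone.

Compound 1 `c1cncc(N2C[C@@H]3CCNC[C@@H]32)c1` and compound 2 `Clc1ccc(N2C[C@@H]3CCNC[C@@H]32)cn1` share a single core and differ only at one aromatic carbon. In a functional assay on HEK293 cells for agonist activity at Neuronal acetylcholine receptor; alpha3/beta4 (Homo sapiens), read by FLIPR (on this read-out higher numbers stand for an effect only at larger amounts of compound and lower numbers for an effect already at smaller amounts), compound 1 gives 1700 nM, and compound 2 gives 1390 nM; these two numbers lie within the scatter of each other, as the step of a 1.2-fold lower number from compound 1 to compound 2 (0.09 log units; within the scatter) shows. Compound 3 `Clc1cc(N2C[C@@H]3CCNC[C@@H]32)cnc1Cl` carries one further change: chloro in place of hydrogen on an aromatic carbon. Among the measured compounds shown here, the only measured step that bears on this change, a 1.2-fold lower number from compound 1 to compound 2 (0.09 log units; within the scatter), stayed within the scatter, so compound 3 is expected to show no step beyond the scatter in this assay, the expected step being a 1.2-fold lower number from compound 2 to compound 3 (0.06 log units; within the scatter). Compound 3 is therefore estimated at 1200 nM, within a range from 500 nM to 3000 nM.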

Compound 3, half-maximal effective concentration: 4110 nM
The estimate for compound 3 lay 3.4-fold (0.53 log units) below the measured number, outside the stated range (above it).
By their numbers in this assay, from the lowest: compounds 2 and 1 (each within the scatter of the next); then compound 3.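

The step of a 3.0-fold higher number from compound 2 to compound 3 (0.47 log units; beyond the scatter) lies beyond the scatter in this assay while a 1.2-fold lower number from compound 1 to compound 2 (0.09 log units; within the scatter) stays within it, so the same change does not read the same at both aromatic carbons. On the carbon ortho to a chloro group and two atoms from the ring nitrogen, chloro in place of hydrogen means the effect needs a larger amount of compound. Nothing at hand accounts for this difference between the two steps.

Going by these compounds, whether a methyl group or an amine at this carbon would shift the number as chloro does stays open. So does whether this step depends on the chloro group already present on the ring.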